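The source may report more compounds than this note shows. Statements on the series, on what has been measured and on what is new or still open speak of the compounds shown alone.

Measured so far:
- Compound 1 `Cc1ccc(-c2cn(Cc3ccccc3)c3c2CNCC3)cc1`: 35 nM
- Compound 2 `COc1ccc(-c2cn(Cc3ccccc3)c3c2CNCC3)cc1`: 290 nM
- Compound 3 `CN1CCc2c(c(-c3ccc(Cl)cc3)cn2Cc2ccccc2)C1`: 36 nM

In an assay on HEK293 cells for displacement of a labelled ligand from 5-hydroxytryptamine receptor 7 (Rattus norvegicus), with a stated time of 60 min (a higher number here means a weaker inhibitor, a lower number a stronger inhibitor), compound 3 stands second highest of the three numbers; its value and that of compound 1 lie within the scatter of each other, while compound 2 sits clearly higher. Within the data shown here, the only step known, an 8.3-fold higher number from compound 1 to compound 2 (0.92 log units; beyond the scatter), concerns the aryl substituent and not the ring amine.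

Compound 4 `CCN1CCc2c(c(-c3ccc(Cl)cc3)cn2Cc2ccccc2)C1` differs from compound 3 by methyl in place of hydrogen on a saturated chain carbon bound to an amine nitrogen in a ring. Among the measured compounds shown here, no measured step touches this position, so nothing in the data argues for a shift beyond the scatter; the expected step is a 1.4-fold higher number from compound 3 to compound 4 (0.14 log units; within the scatter). For compound 4 in this assay the estimate is 50 nM, with a range from 15 nM to 200 nM.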

Compound 4, inhibition constant: 250 nM
Beside the measured number, compound 4's estimate is 5.0-fold (0.70 log units) below it; the measured number lies above the stated range.
By their numbers in this assay, from the lowest: compounds 1 and 3 (each within the scatter of the next); then compounds 4 and 2 (each within the scatter of the next).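

The step of a 6.9-fold higher number from compound 3 to compound 4 (0.84 log units; beyond the scatter) shows that methyl to ethyl on the ring amine, a change of one carbon, is enough to move the number beyond the scatter in this assay. Among these compounds, until now, the only measured step concerned the aryl substituent, so this is the first sign that the ring amine position also matters. The data offer no explanation for this step.

From the compounds shown here alone, it remains open whether a longer chain, such as propyl, or a benzyl group on the ring amine would raise the number further. Also open, going by these compounds, is whether methyl to ethyl has a similar effect with a methyl or methoxy aryl substituent.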